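Swapping Phenyl for Neopentyl on a Second Core

The source may hold more compounds than are shown below. What is called first, only, known or untested is meant among the compounds shown, and "the series" means these compounds.

Measured so far:
Compound 1 `O=C(NCc1cc(Cl)ccc1-n1cnnn1)[C@@H]1CC=NN1C(=O)[C@H](O)c1ccccc1` gives 7 10^-6 cm/s in an ADME assay on Caco-2 cells (Homo sapiens) for permeability, read by LC-MS, in the apical to basolateral direction, with a stated time of 60 min, at pH 6.5; on this read-out higher numbers stand for higher permeability and lower numbers for lower permeability.
Compound 2 `CC(C)(C)C[C@@H](O)C(=O)N1N=CC[C@H]1C(=O)NCc1cc(Cl)ccc1-n1cnnn1` gives 24 10^-6 cm/s.
Compound 3 `O=C(NCc1cc(Cl)ccc1-n1cnnn1)[C@@H]1[C@H]2C[C@H]2CN1C(=O)[C@H](O)c1ccccc1` gives 12 10^-6 cm/s.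

Compound 2 differs from compound 1 in one place, (neopentyl in place of phenyl on a saturated chain carbon bound to a carbonyl carbon and an oxygen on a saturated carbon), and this change produced a 3.4-fold higher number from compound 1 to compound 2 (0.54 log units; beyond the scatter). Compound 3 has a different core from compound 1; the difference between the two cores is not broken down here. Compound 3 and compound 1 give numbers that lie within the usual scatter of each other, as do compound 3 and compound 2, so nothing can be said about their order.

Compound 4 `CC(C)(C)C[C@@H](O)C(=O)N1C[C@@H]2C[C@@H]2[C@H]1C(=O)NCc1cc(Cl)ccc1-n1cnnn1` has not yet been measured in this assay. It differs from compound 3 by neopentyl in place of phenyl on a saturated chain carbon bound to a carbonyl carbon and an oxygen on a saturated carbon, the same change already seen between compound 1 and compound 2, made this time on the core of compound 3. Because that earlier change gave a 3.4-fold higher number from compound 1 to compound 2 (0.54 log units; beyond the scatter), a comparable but somewhat smaller step, a 2.8-fold higher number from compound 3 to compound 4 (0.45 log units; beyond the scatter), is expected here, allowing for the change of core. Compound 4 is therefore estimated at 34 10^-6 cm/s, with a likely range from 18 10^-6 cm/s to 60 10^-6 cm/s.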

Compound 4, apparent permeability: 25 10^-6 cm/s
Beside the measured number, compound 4's estimate is 1.4-fold (0.13 log units) above it; the range from low to high includes it.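

In this assay, putting neopentyl in place of phenyl on the core of compound 3 gave a 2.1-fold higher number from compound 3 to compound 4 (0.32 log units; beyond the scatter), the same direction as on the core of compound 1. Set side by side, the two steps cannot be told apart in size: the same change on two cores in this assay, a 3.4-fold higher number (0.54 log units; beyond the scatter) from compound 1 to compound 2 and a 2.1-fold higher number (0.32 log units; beyond the scatter) from compound 3 to compound 4, 1.6-fold (0.22 log units) apart, within the scatter of two such steps. So within this pair of cores the change carries over in both direction and size, but this does not show that it would do so on a third core, and two steps alone cannot explain why the number moves.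

The compounds shown compare only phenyl and neopentyl at this place, so it remains open how a group such as a longer chain, an amine or a carboxylic acid would behave there. On these data alone, it also remains open whether either of these groups would give the same result in any other measurement, since the comparison here rests on a single read-out.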